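Sulfonyl aryl swap from compound 2 to compound 3

A few compounds are considered here, and "the series" means these few. Any claim that something is new, unique, unknown or untested is made for them only; others in the source may bear on it.

Measured so far:
- Compound 1 `Cc1ccccc1S(=O)(=O)Nc1ccc2oc(-c3ccccc3)nc2c1`: in an assay on isolated protein for inhibition of malate dehydrogenase, mitochondrial (Sus scrofa), with stated times of 45 min and 30 min (on this read-out higher numbers stand for weaker inhibition and lower numbers for stronger inhibition), compound 1 gives > 63000 nM, which is a limit of the assay and not a number.
- Compound 2 `COc1ccc(S(=O)(=O)Nc2ccc3oc(-c4ccccc4)nc3c2)cc1`: in this assay compound 2 gives > 63000 nM, likewise a limit of the assay and not a number.

Among the measured compounds shown here, the only single-point change measured, from compound 1 to compound 2, is a step that the two limits leave unreadable from compound 1 to compound 2. Compound 2 therefore stands nowhere definite on the numbers shown: its value is a limit, and the one further value shown is also a limit, as summarised by the limit of > 63000 nM in this assay, at which 2 of the 2 values shown sit. No readable step exists in this assay on which to base a direction.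

Compound 3 `O=S(=O)(Nc1ccc2oc(-c3ccccc3)nc2c1)c1ccc(Cl)c(Cl)c1` differs from compound 2 by 3,4-dichlorophenyl in place of 4-methoxyphenyl on a sulfonyl sulfur. Because the single measured step is a step that the two limits leave unreadable from compound 1 to compound 2, nothing shown sets the size or direction of the change in inhibition from a swap on the sulfonyl sulfur; both neighbours of compound 3 in the series sit at the limit. The working expectation for compound 3 is that this assay again returns a limit rather than a number, with the estimated value for compound 3 at 90000 nM and a range from 25000 nM to 400000 nM. The step from compound 2 to compound 3 is thus expected to be a step that the limit leaves unreadable from compound 2 to compound 3, not separable from the scatter.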

Compound 3, half-maximal inhibitory concentration: > 63000 nM
Compound 3 was reported as a limit; the forecaster's own chance of this, stated with the estimate: 80%; the middle value is on the limit's open side.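

In this assay compound 3 gives > 63000 nM, which is a limit of the assay and not a number. No step among compound 1, compound 2 and compound 3 can be read, since all of the values are limits: the limit of > 63000 nM in this assay, at which 3 of the 3 values shown sit.

The compounds shown leave open whether any group on the sulfonyl sulfur brings inhibition to a readable number.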